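Series notes: aryl exchange next to the ring sulfur

The source may hold more compounds than are shown below. What is called first, only, known or untested is meant among the compounds shown, and "the series" means these compounds.

Three members of the series have been measured in an assay on CHO cells for displacement of a labelled ligand from adenosine receptor A1 (Homo sapiens), read by scintillation counting, tested at 10 uM; on this read-out higher numbers stand for more inhibition at the one concentration tested (going by the name of the read-out) and lower numbers for less inhibition. Compound 1 `CC(C)Cc1csc(N)c1C(=O)c1ccc(Cl)cc1` gives 1%, compound 2 `Cc1c(Br)sc(N)c1C(=O)c1ccc(Cl)cc1` gives 1%, and compound 3 `CC(C)(C)Cc1c(-c2cccnc2)sc(N)c1C(=O)c1ccc(Cl)cc1` gives 1%. On these numbers compound 3 stands level with compound 1 and compound 2 at the digits shown; the three values lie within the scatter of one another, so no order among them can be read. Among the compounds with values here, no pair of measured compounds differs in one place only, so no step between measured compounds is available as a guide.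

Compound 4 `CC(C)(C)Cc1c(-c2ccc(F)cc2F)sc(N)c1C(=O)c1ccc(Cl)cc1` is the next compound to be measured in this assay. Compared with compound 3 it carries 2,4-difluorophenyl in place of pyridin-3-yl on an aromatic carbon. All three measured compounds sit at the same low read-out whatever group stands next to the ring sulfur, so the expected step is a number 1 percentage points higher from compound 3 to compound 4 (within the scatter), none beyond the scatter. The estimate for compound 4 in this assay is 2%, with an expected range from -8% to 12%.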

Compound 4, a percentage reported as inhibition, at one concentration (the size of the read-out at that concentration, not a potency): 1%
For compound 4 the middle estimate is 1 percentage points above the measured one; the measured number falls inside the stated range.
By their numbers in this assay, from the lowest: compounds 1, 2, 3 and 4 (each within the scatter of the next).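

In this assay, within the data shown here, 2,4-difluorophenyl in place of pyridin-3-yl on an aromatic carbon next to the ring sulfur gives no change at the digits printed from compound 3 to compound 4 (within the scatter), the first step that differs in one place only. At this position, with the neopentyl group held fixed, exchanging a ring that has a hetero atom and a hydrogen-bond acceptor for a ring of carbon only leaves the read-out within the scatter. No other measurement bears on why this is so.

Since this pair sits at the low end of the read-out, it cannot show whether the position matters in compounds with a higher read-out. Going by these compounds, whether an amine, a carboxylic acid or a longer chain at this position would move the read-out beyond the scatter remains open.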